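A few compounds are considered here, and "the series" means these few. Any claim that something is new, unique, unknown or untested is made for them only; others in the source may bear on it.

Compound 1 `Cc1cn([C@@H]2O[C@H](CO[Si](C)(C)C(C)(C)C)[C@@]3(OS(=O)(=O)C=C3NCCC(=O)OCc3ccccc3)[C@H]2O[Si](C)(C)C(C)(C)C)c(=O)n(C)c1=O` carries a 2-(benzyloxycarbonyl)ethyl group on the amine nitrogen of the shared core. In a functional assay on HEL cells (Homo sapiens) for cytotoxicity, read by microscopy (on this read-out lower numbers stand for higher toxicity in this test and higher numbers for lower toxicity in this test), compound 1 reaches only the limit >= 400000 nM. Compound 2 `COC(=O)C(=O)CNC1=CS(=O)(=O)O[C@@]12[C@@H](CO[Si](C)(C)C(C)(C)C)O[C@@H](n1cc(C)c(=O)n(C)c1=O)[C@@H]2O[Si](C)(C)C(C)(C)C` likewise stops at the limit > 400000 nM. Compound 3 `COC(=O)CCNC1=CS(=O)(=O)O[C@@]12[C@@H](CO[Si](C)(C)C(C)(C)C)O[C@@H](n1cc(C)c(=O)n(C)c1=O)[C@@H]2O[Si](C)(C)C(C)(C)C` also stops at the limit >= 400000 nM. Hence the steps a step that the two limits leave unreadable from compound 1 to compound 2, a step that the two limits leave unreadable from compound 1 to compound 3 and a step that the two limits leave unreadable from compound 2 to compound 3 have no readable size, since all three values sit at limits the limit of > 400000 nM in this assay, at which 1 of the 3 values shown sits, and (the limit of >= 400000 nM in this assay, at which 2 of the 3 values shown sit). Compound 4 `CC(=O)NC1=CS(=O)(=O)O[C@@]12[C@@H](CO[Si](C)(C)C(C)(C)C)O[C@@H](n1cc(C)c(=O)n(C)c1=O)[C@@H]2O[Si](C)(C)C(C)(C)C` differs from compound 1 by acetyl in place of 2-(benzyloxycarbonyl)ethyl on an amine nitrogen. The measured steps bearing on this change, all at the amine nitrogen, give no readable size, so no step beyond the scatter is expected in this assay. Compound 4 is therefore estimated at 400000 nM, ranging from 200000 nM to 800000 nM, with an expected step of a number no higher from compound 1 to compound 4 (the limit leaves the size open).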

Compound 4, minimum cytotoxic concentration: >= 80000 nM
Compound 4 ended at the assay's limit; the forecaster's own chance of this, stated with the estimate: 85%; the middle value does not contradict the limit.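

Compound 4, like compound 1, compound 2 and compound 3, stands only at a limit in this assay, so none of its steps to those compounds can be read. The compounds shown leave open whether any group on the amine nitrogen changes the minimum cytotoxic concentration.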